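The source may hold more compounds than are shown below. What is called first, only, known or untested is meant among the compounds shown, and "the series" means these compounds.

Measured in a functional assay on PANC-1 cells (Homo sapiens) for inhibition, read by MTT assay, with a stated time of 24 h; on this read-out higher numbers stand for weaker inhibition and lower numbers for stronger inhibition:
compound 1 `CC1(C)[C@H]2CC[C@]1(C)N(Cc1cn(-c3ccccc3Br)nn1)C(=O)C2`: 280 nM
compound 2 `Cc1ccc(-n2cc(CN3C(=O)C[C@@H]4CC[C@@]3(C)C4(C)C)nn2)cc1`: 270 nM
Not yet measured: compound 3 `CC1(C)[C@H]2CC[C@]1(C)N(Cc1cn(-c3cccc(Br)c3)nn1)C(=O)C2`

For the measured compounds named here, only two numbers are available so far, and compound 2, at 270 nM, cannot be separated from compound 1. Going by the values given here, the only measured step, a 1.0-fold lower number from compound 1 to compound 2 (0.02 log units; within the scatter), put 4-methylphenyl in place of 2-bromophenyl on an aromatic nitrogen.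

The next change acts at that same nitrogen: 3-bromophenyl in place of 4-methylphenyl on an aromatic nitrogen. In words, 3-bromophenyl replaces 4-methylphenyl, while the shared core stays as it is. Among the compounds with values here, no compound carrying 3-bromophenyl has been measured, so the evidence is thin and comes from a single comparison at this place.

Since a 1.0-fold lower number from compound 1 to compound 2 (0.02 log units; within the scatter) stayed within the scatter, no step beyond the scatter is expected in this assay, and no direction can be assigned with confidence. The estimated change is a 1.0-fold higher number from compound 2 to compound 3 (0.02 log units; within the scatter). For compound 3 the expected value is 280 nM, with an estimated range from 120 nM to 650 nM.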

Compound 3, half-maximal inhibitory concentration: 90 nM
Compound 3: the middle estimate sits 3.1-fold (0.49 log units) above what was measured, and the stated range ends above it.
By their numbers in this assay, from the lowest: compound 3; then compounds 2 and 1 (each within the scatter of the next).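

In this assay the group on the aromatic nitrogen now matters: 3-bromophenyl in place of 4-methylphenyl gives a 3.0-fold lower number from compound 2 to compound 3 (0.48 log units; beyond the scatter) and so moves the read-out beyond the scatter, which the earlier step between compound 1 and compound 2 did not do. The step with 3-bromophenyl in place of 2-bromophenyl gives a 3.1-fold lower number from compound 1 to compound 3 (0.49 log units; beyond the scatter) and shows that carrying a bromine is not enough, since both groups are bromophenyl and only compound 3 stands apart, with stronger inhibition on this read-out. No accompanying measurement in the series offers an account of this shift.

Going by these compounds, it remains open whether the stronger inhibition belongs to the bromine itself or would also appear with 3-chlorophenyl, 3-methylphenyl or 3-methoxyphenyl, and 4-bromophenyl would complete the set of bromine placements alongside compound 1 and compound 3. Also open, on these data alone, is how this position responds to a group of a different kind on the phenyl ring, such as an amine or a carboxylic acid, and whether the 3-bromophenyl step holds with the phenyl ring replaced by a pyridine.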